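Adding a Third Fluorine to a Receptor Antagonist

This account rests on a few compounds, and the source may have more. Where it says the series, first, only, none or still open, it means among the compounds named here.

Compound 1, `Cc1cc(COc2ccccc2)nc(-c2ccccn2)n1`: 794 nM
Compound 2, `Cc1cc(COc2ccc(F)cc2)nc(-c2ccccn2)n1`: 631 nM
Compound 3, `Cc1cc(COc2cccc(F)c2F)nc(-c2ccccn2)n1`: 398 nM

All three were tested in a functional assay on cells for antagonist activity at Free fatty acid receptor 1 (Homo sapiens), read by TR-FRET and inositol phosphate accumulation, with a stated time of 2 h; a lower number here means a stronger inhibitor, a higher number a weaker inhibitor. Compound 2 differs from compound 1 in one place: fluoro in place of hydrogen on an aromatic carbon That change gave a 1.3-fold lower number from compound 1 to compound 2 (0.10 log units; within the scatter). Compound 3 has a different core from compound 1; the difference between the two cores is not broken down here. Compound 4, `Cc1cc(COc2c(F)ccc(F)c2F)nc(-c2ccccn2)n1`, has not yet been measured in this assay. It differs from compound 3 in one place: fluoro in place of hydrogen on an aromatic carbon This is the same kind of change as that from compound 1 to compound 2, not the same: in compound 2 the fluoro sits para to a large group, while in compound 4 it sits ortho to a large group, meta to a fluoro group and para to a fluoro group. A small step is expected from compound 3 to compound 4, a 1.2-fold lower number from compound 3 to compound 4 (0.09 log units; within the scatter), because the earlier step of this kind a 1.3-fold lower number from compound 1 to compound 2 (0.10 log units; within the scatter) was small. Compound 4 is therefore estimated at 320 nM in this assay, with a likely range from 130 nM to 800 nM.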

Compound 4, half-maximal inhibitory concentration: 1580 nM
Estimate against measurement, compound 4: 4.9-fold (0.69 log units) below; measured number outside the range, above it.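

In this assay, placing a third fluoro on the aromatic ring gave a 4.0-fold higher number from compound 3 to compound 4 (0.60 log units; beyond the scatter) and so made compound 4 the weaker inhibitor of this pair. Set beside the earlier step, the same swap of hydrogen for fluoro does not carry over unchanged from one core to the other: the same change on two cores in this assay, a 1.3-fold lower number (0.10 log units; within the scatter) from compound 1 to compound 2 and a 4.0-fold higher number (0.60 log units; beyond the scatter) from compound 3 to compound 4, 5.0-fold (0.70 log units) apart, beyond the scatter of two such steps. This does not show what sets the two steps apart: the new fluoro in compound 2 sits para to a large group, while that in compound 4 sits ortho to a large group, meta to a fluoro group and para to a fluoro group, so the core and the place of the fluoro change together, and a single pair on each core gives no general rule.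

As far as these compounds go, it remains open whether a single fluoro at that place would give the same step without the other two. Also open, from the compounds shown here alone, is how a chloro group, a methoxy group or a carboxylic acid on that aromatic carbon would compare with fluoro.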